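A few compounds are considered here, and "the series" means these few. Any claim that something is new, unique, unknown or untested is made for them only; others in the source may bear on it.

Measured so far in a functional assay on CCRF-CEM cells (Homo sapiens) for cytotoxicity, read by MTT assay, with a stated time of 72 h; on this read-out lower numbers stand for stronger inhibition of growth and higher numbers for weaker inhibition of growth:
compound 1, `C=CCOC(=O)Nc1ccc([Se]C#N)cc1`: 9200 nM
compound 2, `N#C[Se]c1ccc(NC(=O)Oc2ccccc2)cc1`: 22900 nM
compound 3, `CC(C)COC(=O)Nc1ccc([Se]C#N)cc1`: 9300 nM

Compound 2 gives the highest of the three numbers. Its nearest neighbour is compound 3, reached by a 2.5-fold lower number from compound 2 to compound 3 (0.39 log units; beyond the scatter); the other direction from compound 1 to compound 2 is a 2.5-fold higher number from compound 1 to compound 2 (0.40 log units; beyond the scatter). Between compound 1 and compound 3 the step is a 1.0-fold higher number from compound 1 to compound 3 (0.00 log units; within the scatter).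

Compound 4, `COc1ccc(OC(=O)Nc2ccc([Se]C#N)cc2)cc1`, keeps the phenyl carbamate of compound 2 and differs from it only by methoxy in place of hydrogen on an aromatic carbon. Among the compounds with values here, none of the measured steps touches that aromatic ring: each of them exchanges the whole group on the oxygen next to the carbonyl group. Within the data shown here, they show only that changes at that end of the molecule moved this assay modestly, and nothing among them speaks for a large effect of a methoxy on the ring. The step from compound 2 to compound 4 is therefore expected to be small, a 1.1-fold lower number from compound 2 to compound 4 (0.06 log units; within the scatter), with no clear direction. Compound 4 is estimated at 20000 nM in this assay, between 8000 nM and 50000 nM.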

Compound 4, concentration for 50% growth inhibition: 13000 nM
For compound 4 the middle estimate is 1.5-fold (0.19 log units) above the measured one, within the range that was stated.
By their numbers in this assay, from the lowest: compounds 1, 3, 4 and 2 (each within the scatter of the next, the first and the last beyond it).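

In this assay, methoxy in place of hydrogen on the aromatic ring of the phenyl carbamate, para to a large group, gives a 1.8-fold lower number from compound 2 to compound 4 (0.25 log units; within the scatter) and so stays within the scatter. The earlier steps shown here each exchanged the whole group on the oxygen next to the carbonyl group, so they could not show how a substituent on this ring would read. This one position on the ring takes a methoxy with no change in growth inhibition that can be told from the scatter, and nothing available explains the result.

On these data alone, how an amine or a carboxylic acid at the same place on the ring would read stays open, as does a longer chain in place of the methoxy. As far as these compounds go, whether this step would hold on any other carbon of that ring also stays open.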